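Methyl on a ring carbon across two pyrimidine-type cores

The source may hold more compounds than are shown below. What is called first, only, known or untested is meant among the compounds shown, and "the series" means these compounds.

Measured compounds:
compound 1, `COc1cc(CC(O)(COCc2ccccc2)COCc2ccccc2)nc(OC)n1`, > 100000 nM
compound 2, `COc1nc(CC(O)(COCc2ccccc2)COCc2ccccc2)c(C)c(OC)n1`, 3500 nM
compound 3, `C[Si](C)(C)CCOCn1c(CC(O)CO)cc(=O)[nH]c1=O`, > 100000 nM

In a functional assay on SW-620 cells (Homo sapiens) for antiproliferative activity, read by MTT assay, with a stated time of 72 h (on this read-out lower numbers stand for stronger inhibition and higher numbers for weaker inhibition), compound 1 gives only a limit, > 100000 nM. Compound 2 gives 3500 nM. The change between them is methyl in place of hydrogen on an aromatic carbon, and the step is an at least 28-fold lower number from compound 1 to compound 2 (1.45 log units; beyond the scatter). For compound 3 the assay likewise reports only a limit, > 100000 nM. The difference between the core of compound 1 and the core of compound 3 is not broken down here. Compound 4, `Cc1c(CC(O)CO)n(COCC[Si](C)(C)C)c(=O)[nH]c1=O`, is not yet measured; it arises from compound 3 by methyl in place of hydrogen on an aromatic carbon. This is the same kind of change as from compound 1 to compound 2, but the surroundings differ: in compound 2 the methyl sits ortho to a large group, ortho to a methoxy group and para to a methoxy group, whereas in compound 4 it sits ortho to a 2,3-dihydroxypropyl group, ortho to a group of 1 heavy atom, meta to a group of 8 heavy atoms and para to a group of 1 heavy atom. Because both starting points sit at the limit of > 100000 nM in this assay, at which 2 of the 3 values shown sit, the earlier step is itself only a lower bound. For compound 4 a step of an at least 3.3-fold lower number from compound 3 to compound 4 (0.52 log units; beyond the scatter) is expected, smaller than the measured one, resting on the step of an at least 28-fold lower number from compound 1 to compound 2 (1.45 log units; beyond the scatter) carried onto a different core. Compound 4 is estimated at 30000 nM, between 4000 nM and 150000 nM.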

Compound 4, half-maximal inhibitory concentration: > 100000 nM
Compound 4: a limit, no number (the forecaster's own chance of this, stated with the estimate: 40%); at least 3.3-fold (0.52 log units) between middle value and limit.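

In this assay compound 3 and compound 4 each give only a limit and not a number, so no step between them can be read: the limit of > 100000 nM in this assay, at which 3 of the 4 values shown sit.

Still open, going by these compounds, is whether methyl in place of hydrogen on an aromatic carbon changes the read-out at all on the core of compound 3, as it does on the core of compound 1.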